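From 4-nitrophenyl to 2-hydroxyphenyl: expecting little change

The source may report more compounds than this note shows. Statements on the series, on what has been measured and on what is new or still open speak of the compounds shown alone.

Compound 1 `COc1ccc(/C=N/NC(=O)c2cn(C3CC3)c3cc(N4CCNCC4)c(F)cc3c2=O)cc1O`: 25000 nM
Compound 2 `O=C(N/N=C/c1ccc([N+](=O)[O-])cc1)c1cn(C2CC2)c2cc(N3CCNCC3)c(F)cc2c1=O`: 25000 nM

In a toxicity assay on CHO cells (Cricetulus griseus) for cytotoxicity, read by MTT assay (on this read-out higher numbers stand for weaker inhibition and lower numbers for stronger inhibition), compound 2 gives 25000 nM, level with compound 1 at 25000 nM. Compound 3 `O=C(N/N=C/c1ccccc1O)c1cn(C2CC2)c2cc(N3CCNCC3)c(F)cc2c1=O` has 2-hydroxyphenyl in place of 4-nitrophenyl on a carbon with a double bond to nitrogen. For the measured compounds named here, only one measured step bears on this place, no change at the digits printed from compound 1 to compound 2 (within the scatter), and it lies within the scatter. Two compounds are thin evidence, but a large move seems unlikely. The expected result in this assay is no change at the digits printed from compound 2 to compound 3 (within the scatter), nothing beyond the scatter. For compound 3 the estimated value is 25000 nM, within an expected range of 12000 nM to 45000 nM.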

Compound 3, half-maximal inhibitory concentration: 25000 nM
Compound 3: the middle estimate sits on the measured number at the digits printed; the range from low to high includes it.
By their numbers in this assay, from the lowest: compounds 1, 2 and 3 (each within the scatter of the next).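

With 2-hydroxyphenyl on the carbon with a double bond to nitrogen, this assay shows no change at the digits printed from compound 2 to compound 3 (within the scatter) and also no change at the digits printed from compound 1 to compound 3 (within the scatter). A hydrogen-bond donor enters as 4-nitrophenyl leaves, and three differently substituted phenyl groups at this place now read alike. Nothing measured here explains this.

All three compounds keep a six-membered aromatic ring of carbon only at this place. On these data alone, what an amine or a carboxylic acid on that ring, or a longer chain in its place, would do stays open, as does any change to the shared core.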